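Amide aryl variation on a shared azo-indole core

The compounds below may be only part of what the source reports. "The series", "measured", "known", "first", "only" and "open" are said of these compounds alone.

Measured so far:
compound 1, `Cc1ccc(NC(=O)c2ccc(/N=N\c3c[nH]c4ccccc34)cc2)cc1`: in a functional assay on P388 cells (Mus musculus) for inhibition, read by MTT assay, with a stated time of 72 h (on this read-out higher numbers stand for weaker inhibition and lower numbers for stronger inhibition), compound 1 gives 300 nM
compound 2, `Cc1cccc(NC(=O)c2ccc(/N=N\c3c[nH]c4ccccc34)cc2)c1C`: in this assay compound 2 gives 51600 nM
compound 3, `Cc1ccc(NC(=O)c2ccc(/N=N\c3c[nH]c4ccccc34)cc2)c(C)c1`: in this assay compound 3 gives 190000 nM

Compound 3 stands at the highest number of the three. The step of a 630-fold higher number from compound 1 to compound 3 (2.80 log units; beyond the scatter) separates it from compound 1, and the step of a 3.7-fold higher number from compound 2 to compound 3 (0.57 log units; beyond the scatter) from compound 2. The other step seen, a 170-fold higher number from compound 1 to compound 2 (2.24 log units; beyond the scatter), points the same way: both compounds carrying a methyl on the amide aryl ring in addition to the pattern of compound 1 sit far above compound 1.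

Compound 4, `O=C(Nc1cccc(Cl)c1)c1ccc(/N=N\c2c[nH]c3ccccc23)cc1`, has not been measured. It differs from compound 3 by 3-chlorophenyl in place of 2,4-dimethylphenyl on an amide-type nitrogen. Within the data shown here, no measured step covers this exact exchange. What bears on it is indirect: the two large steps from compound 1, a 170-fold higher number from compound 1 to compound 2 (2.24 log units; beyond the scatter) and a 630-fold higher number from compound 1 to compound 3 (2.80 log units; beyond the scatter), show that the aryl pattern on the amide nitrogen moves this assay strongly, and compound 4 returns to a single substituent on that ring, as in compound 1. Among the measured compounds shown here, on that basis a large step downward is expected, a 63-fold lower number from compound 3 to compound 4 (1.80 log units; beyond the scatter), though with wide uncertainty, since chlorine has no precedent here. Compound 4 is therefore estimated at 3000 nM, with a range from 300 nM to 60000 nM.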

Compound 4, half-maximal inhibitory concentration: 267000 nM
The estimate for compound 4 lay 89-fold (1.95 log units) below the measured number, outside the stated range (above it).
By their numbers in this assay, from the lowest: compound 1; then compound 2; then compounds 3 and 4 (each within the scatter of the next).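

In this assay, a single substituent on the ring at the amide-type nitrogen does not by itself restore the number of compound 1, as an 890-fold higher number from compound 1 to compound 4 (2.95 log units; beyond the scatter) shows: 3-chlorophenyl ends up far from 4-methylphenyl, in the same region as the two dimethylphenyl compounds. The exchange for 2,4-dimethylphenyl gives a 1.4-fold higher number from compound 3 to compound 4 (0.15 log units; within the scatter), and the exchange for 2,3-dimethylphenyl gives a 5.2-fold higher number from compound 2 to compound 4 (0.71 log units; beyond the scatter), so among these four compounds the count of substituents on this ring does not sort the numbers, and only compound 1 stands apart. No supporting measurement bears on why the 4-methylphenyl group of compound 1 differs from the other three aryl groups.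

From the compounds shown here alone, what a 4-chlorophenyl, a 3-methylphenyl or an unsubstituted phenyl would give on the same nitrogen remains open, and with it whether the low number of compound 1 depends on the methyl group, on where it sits, or on both. Also open, going by these compounds, is whether a 4-methoxyphenyl or a 4-aminophenyl group would stay near compound 1 or join compounds 2, 3 and 4.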